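The source may report more compounds than this note shows. Statements on the series, on what has been measured and on what is new or still open speak of the compounds shown alone.

Measured compounds:
- compound 1, `CC(C)(C)OC(=O)Nc1ccc(NC(=O)CCc2cccc3c2B(O)OC3)cc1`, gives 29000 nM in a functional assay on MDA-MB-231 cells (Homo sapiens) for antiproliferative activity, read by MTT assay, with a stated time of 72 h; on this read-out higher numbers stand for weaker inhibition and lower numbers for stronger inhibition
- compound 2, `O=C(CCc1cccc2c1B(O)OC2)Nc1cccc(-c2cccc(F)c2)c1`, gives 570 nM in this assay

Among the compounds with values here, of the two numbers known so far, compound 2 stands lowest: in this assay compound 2 gives 570 nM, while compound 1 gives a far higher number, a gap well beyond the usual scatter. Compound 3, `N#Cc1cccc(-c2cccc(NC(=O)CCc3cccc4c3B(O)OC4)c2)c1`, has not yet been measured. It differs from compound 2 in one place: cyano in place of fluoro on an aromatic carbon. Within the data shown here, no pair of measured compounds shows what this exchange does, so the size of the step is uncertain. With the shared core and the amide linkage untouched, the expectation is a step in this assay no larger than the usual scatter, in either direction, with perhaps a slight drift toward weaker inhibition. The estimated step from compound 2 to compound 3 is a 1.3-fold higher number from compound 2 to compound 3 (0.12 log units; within the scatter). Compound 3 is therefore estimated at 750 nM, with a likely range from 250 nM to 2200 nM.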

Compound 3, half-maximal inhibitory concentration: 110 nM
Compound 3: middle estimate off by 6.8-fold (0.83 log units), on the high side; measured number below the stated range.
By their numbers in this assay, from the lowest: compound 3; then compound 2; then compound 1.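

In this assay, exchanging 3-fluorophenyl for 3-cyanophenyl gives a 5.2-fold lower number from compound 2 to compound 3 (0.71 log units; beyond the scatter), with the shared core and the amide linkage unchanged. This is the first change in a single place among these compounds, and it shows that the group on this aromatic carbon, meta to a large group, can move the result beyond the usual scatter, here toward stronger inhibition. Nothing available here explains why cyano gives the lower number.

The compounds shown leave open whether other groups at this position, such as an amine, a carboxylic acid or a methoxy group, would give a similar step or go the other way. They also leave open whether cyano would give the same step on another carbon of this ring.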